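An Ester Changed to an Amide: Expecting Compound 3

The source may report more compounds than this note shows. Statements on the series, on what has been measured and on what is new or still open speak of the compounds shown alone.

Measured compounds:
compound 1, `CC(C)C(=O)N(CC(=O)NCCN)c1ccc([N+](=O)[O-])c(C(F)(F)F)c1`, 24100 nM
compound 2, `CCCCCCCCCCCCOc1cc(OCCCCCCCCCCCC)cc(C(=O)OC)c1`, > 1000000 nM

Of the compounds shown here, two have been measured in a functional assay on U-251 cells (Homo sapiens) for inhibition, read by MTT assay, with a stated time of 48 h; on this read-out higher numbers stand for weaker inhibition and lower numbers for stronger inhibition. Compound 1 gives 24100 nM. Compound 2 gives only > 1000000 nM, which is a limit of the assay and not a number. Compound 2 therefore stands at the limit of > 1000000 nM in this assay, at which 1 of the 2 values shown sits, and nothing more can be said about where it lies beyond that.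

Compound 3 `CCCCCCCCCCCCOc1cc(OCCCCCCCCCCCC)cc(C(=O)NCCN)c1` has not yet been measured. It differs from compound 2 in one place: (2-aminoethyl)amino in place of methoxy on a carbonyl carbon. For the measured compounds named here, the group that enters, read one bond further out as (2-aminoethyl)carbamoyl, is also carried by compound 1, but compound 1 differs from compound 3 in the rest of the molecule, so no measured step describes this change, and what the two values of compound 1 and compound 2 show is only that one is a number and the other a limit.

Since compound 2 is known only as a limit, the size of the step to compound 3 is expected to be uncertain; a move toward stronger inhibition of about an at least 6.6-fold lower number from compound 2 to compound 3 (0.82 log units; beyond the scatter) is expected, though a second limit would not be surprising. For compound 3 the expected value is 150000 nM, with a range from 20000 nM to 1000000 nM.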

Compound 3, half-maximal inhibitory concentration: > 1000000 nM
Compound 3 ended at the assay's limit; the forecaster's own chance of this, stated with the estimate: 40%; middle value at least 6.6-fold (0.82 log units) from the limit.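

In this assay compound 3 gives > 1000000 nM as a limit of the assay and not a number. Compound 2 is known only as a limit too, so no step can be read between compound 2 and compound 3: the limit of > 1000000 nM in this assay, at which 2 of the 3 values shown sit.

The compounds shown leave open whether (2-aminoethyl)amino in place of methoxy on a carbonyl carbon changes inhibition at all.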